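Turning One Stereocentre in Compound 2

This account rests on a few compounds, and the source may have more. Where it says the series, first, only, none or still open, it means among the compounds named here.

Compound 1 `CN1CCC[C@H]1[C@H]1COc2ccc(O)cc2O1`: 310 nM
Compound 2 `CN1CCC[C@H]1[C@H]1COc2ccncc2O1`: 8900 nM

Among the two compounds measured in an assay on HEK293 cells for displacement of a labelled ligand from Neuronal acetylcholine receptor; alpha3/beta4 (Homo sapiens), with a stated time of 5 min (on this read-out higher numbers stand for weaker inhibition and lower numbers for stronger inhibition), compound 2 stands at the higher number, and its nearest neighbour, compound 1, lies well below it, a gap beyond the usual scatter. Compound 3 `CN1CCC[C@H]1[C@@H]1COc2ccncc2O1` keeps every atom and bond of compound 2; the difference is this: the two compounds have the same atoms and bonds and differ only in configuration as drawn: 1 of 2 stereo elements differ; a stereocentre at a saturated ring carbon is drawn S in compound 2 and R in compound 3. For the measured compounds named here, no step between two measured compounds shows what such a change does here, so the expectation rests on nothing more than the weak standing of compound 2 and the nature of a single configurational change. A step of modest size, in either direction, or none beyond the scatter, is what one would expect from compound 2 to compound 3, and the estimate is written as a 1.5-fold lower number from compound 2 to compound 3 (0.17 log units; within the scatter). For compound 3 the expected result in this assay is 6000 nM, with a range from 1500 nM to 25000 nM.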

Compound 3, inhibition constant: 5800 nM
Compound 3: middle estimate off by 1.0-fold (0.01 log units), on the high side; the range from low to high includes it.
By their numbers in this assay, from the lowest: compound 1; then compounds 3 and 2 (each within the scatter of the next).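

Turning the stereocentre at the saturated ring carbon from S to R gives a 1.5-fold lower number from compound 2 to compound 3 (0.19 log units; within the scatter) in this assay. For the compounds shown here, at this position, and on this core, the two configurations therefore cannot be told apart by this read-out, something no earlier pair could show. The comparison isolates that single stereocentre, and nothing else in the structure enters it: the fact that compounds 2 and 3 differ only in the configuration as drawn

The compounds shown leave open whether the same indifference to configuration would hold on the core of compound 1, or on a core carrying another group, such as a methoxy group or an amine. They also leave open what inverting the second stereocentre would do, and whether a longer chain on the ring nitrogen in place of the methyl would change the picture.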